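The compounds below may be only part of what the source reports. "The series", "measured", "known", "first", "only" and "open" are said of these compounds alone.

Of the compounds shown here, two have been measured so far, both built on a shared core that carries an ester and a hydroxymethyl group. Compound 1 `CN(C)c1ccc(C(=O)OCC2(CO)C/C(=C\c3cnc4ccccc4c3)C(=O)O2)cc1` bears a quinolin-3-yl group on its exocyclic double bond; in an assay on cells for displacement of a labelled ligand from Ras guanyl-releasing protein 3 (Homo sapiens) (a lower number here means a stronger inhibitor, a higher number a weaker inhibitor), compound 1 gives 137 nM. Compound 2 `CCCC(CCC)C(=O)OCC1(CO)C/C(=C/c2ccncc2)C(=O)O1` instead bears pyridin-4-yl and a different ester; in this assay compound 2 gives 44 nM. Compound 1 thus stands at the higher of the two numbers, and the gap to compound 2 lies beyond the usual scatter, but the two compounds differ in two places, so the share of either change cannot be read from them.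

Compound 3 `CN(C)c1ccc(C(=O)OCC2(CO)C/C(=C\c3ccncc3)C(=O)O2)cc1` has not yet been measured. It departs from compound 1 in one place: pyridin-4-yl in place of quinolin-3-yl on a double-bonded chain carbon bound to a double-bonded ring carbon. Going by the values given here, a move toward a lower number is expected in this assay, since compound 2, which also carries pyridin-4-yl, gives 44 nM, yet the expected step from compound 1 to compound 3 is kept modest, at a 1.7-fold lower number from compound 1 to compound 3 (0.23 log units; within the scatter), as the ester of compound 2 is not the one in compound 3. For compound 3 the estimate is 80 nM, expected to fall between 30 nM and 220 nM.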

Compound 3, inhibition constant: 54 nM
The estimate for compound 3 lay 1.5-fold (0.17 log units) above the measured number; the range from low to high includes it.
By their numbers in this assay, from the lowest: compounds 2 and 3 (each within the scatter of the next); then compound 1.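

Going by these compounds alone, the pair of compound 1 and compound 3 is the first to isolate a single change. On a double-bonded chain carbon bound to a double-bonded ring carbon, with the ester of compound 1 held fixed, pyridin-4-yl in place of quinolin-3-yl gives a 2.5-fold lower number from compound 1 to compound 3 (0.40 log units; beyond the scatter) in this assay, a share of the change that the gap between compound 1 and compound 2, which differ in more than one place, could not reveal; the second aromatic ring of quinolin-3-yl, the one of carbon only, is thus not needed for a number of this size, and the 10 heavy atoms of that group can give way to 6 without a move toward a weaker inhibitor. Nothing measured here accounts for the step, so the reason for it remains unknown.

The compounds shown leave open whether the ring nitrogen matters at this place, which a plain phenyl ring or a pyridin-3-yl ring would test against pyridin-4-yl. They also leave open how far the ester can be varied while pyridin-4-yl stays in place, for instance with a simple unsubstituted benzoate or a longer alkyl chain.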